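Aryl Swap on the Thiourea of a Cytotoxic Series

The source may report more compounds than this note shows. Statements on the series, on what has been measured and on what is new or still open speak of the compounds shown alone.

Among the measured compounds shown here, compound 1 `CNC(=O)c1cc(Oc2cccc(NC(=S)Nc3ccc(Cl)cc3)c2)ccn1` gives 39400 nM in a functional assay on HCT-116 cells (Homo sapiens) for cytotoxicity, read by MTT assay, with a stated time of 48 h (a higher number here means a weaker inhibitor, a lower number a stronger inhibitor), the highest of the three numbers measured so far. Compound 2 `CC(C)NC(=O)c1cc(Oc2cccc(NC(=S)Nc3ccc(Cl)cc3)c2)ccn1` gives 22100 nM, and compound 3 `O=C(NCc1ccccc1)c1cc(Oc2cccc(NC(=S)Nc3ccc(Cl)cc3)c2)ccn1` gives 16500 nM. The steps of a 1.8-fold lower number from compound 1 to compound 2 (0.25 log units; within the scatter) and a 1.3-fold lower number from compound 2 to compound 3 (0.13 log units; within the scatter) lie within the scatter, while a 2.4-fold lower number from compound 1 to compound 3 (0.38 log units; beyond the scatter) counts as modest. All three measured steps alter the group on the amide-type nitrogen of the core and leave the thiourea aryl untouched. Compound 4 `CNC(=O)c1cc(Oc2cccc(NC(=S)Nc3cccc(C(F)(F)F)c3)c2)ccn1` differs from compound 1 by 3-(trifluoromethyl)phenyl in place of 4-chlorophenyl on an amide-type nitrogen. For the measured compounds named here, no measured step bears on this position, so the expected step is a 1.2-fold lower number from compound 1 to compound 4 (0.09 log units; within the scatter), not beyond the scatter. Compound 4 is therefore estimated at 32000 nM, with a range from 12000 nM to 85000 nM.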

Compound 4, half-maximal inhibitory concentration: 25300 nM
Beside the measured number, compound 4's estimate is 1.3-fold (0.10 log units) above it; the measured number falls inside the stated range.
By their numbers in this assay, from the lowest: compounds 3, 2, 4 and 1 (each within the scatter of the next, the first and the last beyond it).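

Among the compounds shown here, this is the first reading at the thiourea aryl, since the earlier steps changed only the group on the amide-type nitrogen of the core. Putting 3-(trifluoromethyl)phenyl in place of 4-chlorophenyl gives a 1.6-fold lower number from compound 1 to compound 4 (0.19 log units; within the scatter) in this assay, so this exchange does not move the number beyond the scatter. Nothing available bears on why this exchange reads as it does. The compounds shown leave open how a plain phenyl, or an aryl carrying an amine or a carboxylic acid, would read at this nitrogen. They also leave open whether the benzyl of compound 3 and the 3-(trifluoromethyl)phenyl of compound 4 would combine in one molecule.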